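From 2-ethylphenyl to 2,6-dimethoxyphenyl on the shared core

The source may hold more compounds than are shown below. What is called first, only, known or untested is meant among the compounds shown, and "the series" means these compounds.

In an ADME assay on microsomes from liver (Rattus norvegicus) for metabolic stability, read by LC-MS, using NADPH, at 37 degrees C (a lower number here means that the compound disappears faster, a higher number that the compound lasts longer), compound 3 `CCc1ccccc1-c1nc(CN2CCC(C(=O)NCCCN3C[C@H](C)C[C@H](C)C3)CC2)c(C)o1` gives a half-life of 0.283 h. This is the higher of the two exact numbers, the other coming from compound 2 `COc1cccc(Cl)c1-c1nc(CN2CCC(C(=O)NCCCN3C[C@H](C)C[C@H](C)C3)CC2)c(C)o1` at 0.055 h. Compound 1 `Cc1cccc(-c2nc(CN3CCC(C(=O)NCCCN4C[C@H](C)C[C@H](C)C4)CC3)c(C)o2)c1` is recorded only as a limit of the assay, > 0.5 h.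

Compound 4 `COc1cccc(OC)c1-c1nc(CN2CCC(C(=O)NCCCN3C[C@H](C)C[C@H](C)C3)CC2)c(C)o1` carries 2,6-dimethoxyphenyl in place of 2-ethylphenyl on an aromatic carbon. Two measured steps start from compound 1: an at least 9.0-fold lower number from compound 1 to compound 2 (0.95 log units; beyond the scatter) and an at least 1.7-fold lower number from compound 1 to compound 3 (0.24 log units; that floor lies within the scatter). The most telling step is a 5.1-fold higher number from compound 2 to compound 3 (0.71 log units; beyond the scatter), since 2-chloro-6-methoxyphenyl is the measured group that most resembles the incoming one. Compound 4 is therefore expected to fall near compound 2, reversing most of that step in this assay. The expected change is a 3.5-fold lower number from compound 3 to compound 4 (0.55 log units; beyond the scatter), a modest drop beyond the scatter. For compound 4 the estimated half-life is 0.08 h, with an expected range of 0.03 h to 0.22 h.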

Compound 4, half-life: 0.2 h
Compound 4: the middle estimate sits 2.5-fold (0.40 log units) below what was measured, within the range that was stated.
By their numbers in this assay, from the lowest: compound 2; then compounds 4 and 3 (each within the scatter of the next). At a limit, above all of these: compound 1.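

In this assay, for the compounds shown here, the single exchange of methoxy for chloro gives a 3.6-fold higher number from compound 2 to compound 4 (0.56 log units; beyond the scatter), so the low number of compound 2 does not extend to 2,6-dimethoxyphenyl at this position. The exchange of 2-ethylphenyl for 2,6-dimethoxyphenyl gives a 1.4-fold lower number from compound 3 to compound 4 (0.15 log units; within the scatter), so this assay does not separate the two groups, even though the entering group adds two hydrogen-bond acceptors. The step against 3-methylphenyl is an at least 2.5-fold lower number from compound 1 to compound 4 (0.39 log units; beyond the scatter), and the number for compound 1 is a limit of the assay, not an exact value: the limit of > 0.5 h in this assay, at which 1 of the 4 values shown sits.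

The compounds shown leave open where on the molecule the loss occurs and how far chloro alone sets compound 2 apart. A group such as 2-fluoro-6-methoxyphenyl or plain phenyl at this position would bear on the second question.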